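The compounds below may be only part of what the source reports. "The series", "measured", "known", "first", "only" and "open" are said of these compounds alone.

Compound 3, `CCOC(=O)c1cnc(-c2ccc(F)cc2)nc1NN1C(=O)C=C(C)C1=O`, gives 700 nM in a functional assay on Jurkat cells for inhibition of nuclear factor NF-kappa-B complex (Homo sapiens); on this read-out lower numbers stand for stronger inhibition and higher numbers for weaker inhibition. It stands at the low end of the three numbers: compound 2, `CCOC(=O)c1cnc(C(C)(C)C)nc1NN1C(=O)C=C(C)C1=O`, gives 1000 nM, and a 1.4-fold lower number from compound 2 to compound 3 (0.15 log units; within the scatter) is within the scatter, so the two cannot be told apart, while compound 1, `CCOC(=O)c1cnc(CC)nc1NN1C(=O)C=C(C)C1=O`, gives 10000 nM, and a 14-fold lower number from compound 1 to compound 3 (1.15 log units; beyond the scatter) sets it well apart. Compound 4, `CCOC(=O)c1cnc(Cc2ccccc2)nc1NN1C(=O)C=C(C)C1=O`, differs from compound 3 in one place: benzyl in place of 4-fluorophenyl on an aromatic carbon. Of the measured steps, a 10-fold lower number from compound 1 to compound 2 (1.00 log units; beyond the scatter) and a 14-fold lower number from compound 1 to compound 3 (1.15 log units; beyond the scatter) were clearly beyond the scatter, but both started from ethyl, a group not present here. The step that bears most, a 1.4-fold lower number from compound 2 to compound 3 (0.15 log units; within the scatter), swapped one group of similar size for another and stayed within the scatter. Benzyl is again a group of similar make-up to 4-fluorophenyl, so no step beyond the scatter is expected in this assay, with a slight lean toward a higher number. Compound 4 is therefore expected to give about 1000 nM, in a range from 400 nM to 3000 nM. This estimate corresponds to an expected step of a 1.4-fold higher number from compound 3 to compound 4 (0.15 log units; within the scatter).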

Compound 4, half-maximal inhibitory concentration: 7000 nM
Estimate against measurement, compound 4: 7.0-fold (0.85 log units) below, and the stated range ends below it.
By their numbers in this assay, from the lowest: compounds 3 and 2 (each within the scatter of the next); then compounds 4 and 1 (each within the scatter of the next).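

In this assay, this position tells apart two groups that look alike on paper: benzyl and 4-fluorophenyl have the same heavy-atom count and each carries one six-membered aromatic ring, yet a 10-fold higher number from compound 3 to compound 4 (1.00 log units; beyond the scatter) shows that they do not give the same result. Benzyl also separates from tert-butyl, with a 7.0-fold higher number from compound 2 to compound 4 (0.85 log units; beyond the scatter) as the step, while a 1.4-fold lower number from compound 1 to compound 4 (0.15 log units; within the scatter) leaves benzyl and ethyl indistinguishable, so carrying an aromatic ring at this position does not by itself give the lower numbers. Nothing among the data shown gives a reason for this difference.

Benzyl differs from 4-fluorophenyl both in its chain carbon and in lacking fluorine, so plain phenyl would be needed to show which of the two matters. On these data alone, a longer chain such as 2-phenylethyl, or an amine at this position, also remains open.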